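The compounds below may be only part of what the source reports. "The series", "measured", "known", "first", "only" and "open" are said of these compounds alone.

In a functional assay on DU-145 cells (Homo sapiens) for cytotoxicity, read by MTT assay, with a stated time of 48 h (a lower number here means a stronger inhibitor, a higher number a weaker inhibitor), three compounds of a shared core have been measured. Compound 1 `COc1ccc(-c2cc(C(=O)Nc3nc4ccc(Cl)cc4s3)nc3cc(-c4ccccc4)nn23)cc1` gives 5880 nM, compound 2 `COc1ccc(-c2cc(C(=O)Nc3nc4ccc(OC)cc4s3)nc3cc(-c4ccccc4)nn23)cc1` gives 7580 nM, and compound 3 `COc1ccc2nc(NC(=O)c3cc(-c4cc(OC)c(OC)c(OC)c4)n4nc(-c5ccccc5)cc4n3)sc2c1` gives 3980 nM. Compound 2 holds the highest of the three numbers, yet its nearest neighbour is compound 1 and its furthest is compound 3, and both of those gaps stay within the scatter, so none of the three can be called stronger or weaker than the others.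

Compound 4 `COc1ccc(-c2cc(C(=O)Nc3nc4cc(C)c(C)cc4s3)nc3cc(-c4ccccc4)nn23)cc1` is the next member of the series and has not yet been measured. It differs from compound 2 in one place: 5,6-dimethyl-1,3-benzothiazol-2-yl in place of 6-methoxy-1,3-benzothiazol-2-yl on an amide-type nitrogen. The measured steps that touch the same position are limited. The step of a 1.3-fold higher number from compound 1 to compound 2 (0.11 log units; within the scatter) swaps one substituent for another on the benzothiazole ring, and the step of a 1.9-fold lower number from compound 2 to compound 3 (0.28 log units; within the scatter) alters the other end of the molecule; neither moved the number beyond the scatter. Among the measured compounds shown here, nothing among the measured compounds carries a dimethyl pattern on the benzothiazole, so the expectation rests on the observation that changes so far have left the read-out nearly flat. For compound 4 the expected step is a 1.3-fold lower number from compound 2 to compound 4 (0.10 log units; within the scatter), with the number for compound 4 estimated at 6000 nM within a range from 2500 nM to 14000 nM.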

Compound 4, half-maximal inhibitory concentration: 12300 nM
The estimate for compound 4 lay 2.1-fold (0.31 log units) below the measured number; the measured number falls inside the stated range.
By their numbers in this assay, from the lowest: compounds 3, 1, 2 and 4 (each within the scatter of the next, the first and the last beyond it).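

In this assay, among the compounds shown here, the swap on the amide-type nitrogen gives the only step that lies beyond the scatter: a 2.1-fold higher number from compound 1 to compound 4 (0.32 log units; beyond the scatter), a modest step with 5,6-dimethyl-1,3-benzothiazol-2-yl in place of 6-chloro-1,3-benzothiazol-2-yl. The same entering group set against 6-methoxy-1,3-benzothiazol-2-yl gives a 1.6-fold higher number from compound 2 to compound 4 (0.21 log units; within the scatter), which stays within the scatter, so this position shows a readable response only in the comparison with the chloro group, and even that one is small. Nothing at hand accounts for why the two comparisons differ in this way.

It stays open how the number would respond to an amine, a hydroxyl or a carboxylic acid on the 1,3-benzothiazol-2-yl group, since the groups shown there carry only chloro, methoxy and methyl substituents. From the compounds shown here alone, it also stays open whether the gap seen with 5,6-dimethyl-1,3-benzothiazol-2-yl would hold with 3,4,5-trimethoxyphenyl in place of 4-methoxyphenyl at the other end of the molecule.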